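The source may report more compounds than this note shows. Statements on the series, on what has been measured and on what is new or still open speak of the compounds shown alone.

Of the compounds shown here, two have numbers so far in a functional assay on MCF7 cells (Homo sapiens) for antiproliferative activity, read by sulforhodamine B assay, with a stated time of 48 h; a lower number here means a stronger inhibitor, a higher number a weaker inhibitor. There, compound 1 (`COc1ccc(/C=C/C(=O)C(=Cc2ccc(O)c(F)c2)C(=O)/C=C/c2ccc(OC)cc2OC)c(OC)c1`) gives 5450 nM. Compound 2 (`COc1cc(OC)c(/C=C/C(=O)C(=Cc2ccc(O)c(OC)c2)C(=O)/C=C/c2c(OC)cc(OC)cc2OC)c(OC)c1`) gives 1880 nM, the lower of the two numbers, and its gap to compound 1 lies beyond the scatter.

Compound 3 (`COc1cc(OC)c(/C=C/C(=O)C(=Cc2cc(OC)c(O)c(OC)c2)C(=O)/C=C/c2c(OC)cc(OC)cc2OC)c(OC)c1`) follows from compound 2 by a single change: methoxy in place of hydrogen on an aromatic carbon. Methoxy stands in place of hydrogen on an aromatic carbon, ortho to a hydroxy group and meta to a methoxy group, which turns 4-hydroxy-3-methoxyphenyl into 4-hydroxy-3,5-dimethoxyphenyl.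

Among the compounds with values here, no measured pair shows this change on its own, and the data give no direct guide to its size or direction. Within the data shown here, with only two values in hand, a small change in this assay is the working expectation, with no step beyond the scatter and only a slight lean toward a lower number. The expected step, a 1.2-fold lower number from compound 2 to compound 3 (0.07 log units; within the scatter), stays within the scatter. For compound 3 the estimated value is 1600 nM, with an expected range of 650 nM to 4000 nM.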

Compound 3, half-maximal inhibitory concentration: 1030 nM
For compound 3 the middle estimate is 1.6-fold (0.19 log units) above the measured one; measured number inside the range.
By their numbers in this assay, from the lowest: compounds 3 and 2 (each within the scatter of the next); then compound 1.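

Methoxy in place of hydrogen on an aromatic carbon, ortho to a hydroxy group and meta to a methoxy group, gives in this assay a 1.8-fold lower number from compound 2 to compound 3 (0.26 log units; within the scatter), the first single-place comparison available in the series. This position therefore takes the change from 4-hydroxy-3-methoxyphenyl to 4-hydroxy-3,5-dimethoxyphenyl with no step beyond the scatter in either direction, so compound 2 and compound 3 cannot be ranked on these numbers. The series holds no measurement that bears on the reason for this result.

The compounds shown leave open whether any group on this carbon can move the number beyond the scatter, for instance a longer chain such as ethoxy, an amine or a carboxylic acid in place of the new methoxy. They also leave open whether the same methoxy-for-hydrogen change would give a similar step with the rest of the molecule altered, or with the neighbouring hydroxy group replaced by a methoxy group, since this single pair rests on one background in this assay alone.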